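A thiophene swap in a series held at its limit

This account rests on a few compounds, and the source may have more. Where it says the series, first, only, none or still open, it means among the compounds named here.

In an ADME assay on HepG2 cells (Homo sapiens) for cytotoxicity, read by CellTiter-Glo and resazurin assay, with a stated time of 72 h (a higher number here means that more compound is needed for the effect, a lower number that less compound is needed), compound 3 (`CCOC(=O)CCCCCOc1cccc(CN(C(=O)c2ccc(-c3cccc(OC(C)C)c3)cc2)C(C)C)c1`) gives > 26000 nM as a limit of the assay and not a number. Compound 1 (`CCOC(=O)CCCCCOc1cccc(CN(C(=O)c2ccc(-c3cccc(NC(C)=O)c3)cc2)C(C)C)c1`) gives > 26000 nM as the same kind of limit. Compound 2 (`CCOC(=O)CCCCCOc1cccc(CN(C(=O)c2ccc(-c3cnc(OC)nc3OC)cc2)C(C)C)c1`) gives > 26000 nM as a limit too. The series thus stands at the limit of > 26000 nM in this assay, at which 3 of the 3 values shown sit, and no ranking of these compounds is possible.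

Compound 4 (`CCOC(=O)CCCCCOc1cccc(CN(C(=O)c2ccc(-c3ccc(C(C)=O)s3)cc2)C(C)C)c1`) carries 5-acetylthiophen-2-yl in place of the 3-isopropoxyphenyl of compound 3 on an aromatic carbon (5-acetylthiophen-2-yl in place of 3-isopropoxyphenyl on an aromatic carbon) and is otherwise unchanged.

For the measured compounds named here, three measured swaps in this part of the molecule bear on it: a step that the two limits leave unreadable from compound 1 to compound 2 and a step that the two limits leave unreadable from compound 1 to compound 3 and a step that the two limits leave unreadable from compound 2 to compound 3 so none offers a size to carry over, and no compound has yet left the limit. The step expected in this assay is a step that the limit leaves unreadable from compound 3 to compound 4 with no change beyond the scatter and no direction foreseen. Compound 4 is estimated at 28000 nM with an expected range from 13000 nM to 60000 nM and will most likely again be reported only as a limit.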

Compound 4, half-maximal effective concentration: > 26000 nM
Compound 4: no number, only a limit; the forecaster's own chance of this, stated with the estimate: 80%; the middle value lies beyond the limit too.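

For the compounds shown here, no step from compound 1, compound 2 or compound 3 to compound 4 can be read in this assay because each value is a limit of the assay and not a number: the limit of > 26000 nM in this assay, at which 4 of the 4 values shown sit.

The compounds shown leave open how much of each is needed for the effect, and whether any group at this place would bring a compound off the limit.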